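The source may hold more compounds than are shown below. What is called first, only, known or untested is meant among the compounds shown, and "the series" means these compounds.

Measured in an ADME assay on RAW264.7 cells (Mus musculus) for cytotoxicity, read by MTT assay, with a stated time of 24 h; a higher number here means that more compound is tolerated, a lower number that less compound is tolerated:
compound 1 `O=C(Nc1ccc(Cl)cc1F)c1cc(Cl)ccc1O` gives 8000 nM
compound 2 `O=c1oc2ccc(I)cc2c(=O)n1-c1ccc(F)cc1F` gives 15700 nM
compound 3 `O=c1oc2ccc(F)cc2c(=O)n1-c1ccc(F)cc1F` gives 19900 nM

Compound 1 holds the lowest of the three numbers. Its gap to compound 2 is within the scatter, so those two values cannot be ordered; its gap to compound 3 is beyond the scatter, so compound 1 is tolerated at a lower concentration than compound 3 in this assay.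

Compound 4 `O=C(Nc1ccc(Cl)cc1F)c1cc(F)ccc1O` is the unmeasured partner of compound 1. The change is fluoro in place of chloro on an aromatic carbon.

For the measured compounds named here, only one measured step bears on this kind of change: a 1.3-fold higher number from compound 2 to compound 3 (0.10 log units; within the scatter). There fluoro also enters on an aromatic carbon, in place of iodo, on a different core, and the number did not move beyond the scatter. Going by the values given here, no step exists on the core of compound 1 itself, and the step from compound 2 to compound 3 is the only halogen exchange with a measured result. On that basis no step beyond the scatter is expected in this assay for the present change, in either direction; the expected step is a 1.1-fold higher number from compound 1 to compound 4 (0.05 log units; within the scatter).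

Compound 4 is therefore estimated at 9000 nM, with a range from 4500 nM to 18000 nM.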

Compound 4, half-maximal cytotoxic concentration: 7700 nM
For compound 4 the middle estimate is 1.2-fold (0.07 log units) above the measured one; the measured number falls inside the stated range.
By their numbers in this assay, from the lowest: compounds 4, 1, 2 and 3 (each within the scatter of the next, the first and the last beyond it).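

Fluoro in place of chloro on an aromatic carbon, para to a hydroxy group and meta to a large group, gives in this assay a 1.0-fold lower number from compound 1 to compound 4 (0.02 log units; within the scatter) and so provides the first measured halogen exchange on the core of compound 1, one that stays within the scatter. Alongside a 1.3-fold higher number from compound 2 to compound 3 (0.10 log units; within the scatter) on a different core, the series now holds two exchanges in which fluoro enters on an aromatic carbon, and neither moves the number beyond the scatter, although this rests on those two pairs alone. Nothing measured here explains why the number in this assay stays within the scatter for this exchange.

Still open, from the compounds shown here alone, is whether a group of another kind at this position, such as an amine, a methoxy group or a carboxylic acid, would move the number beyond the scatter. Also open, going by these compounds, is how the number responds to a change at the hydroxy group or the amide hydrogen, both of which are common to compound 1 and compound 4.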